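The source may hold more compounds than are shown below. What is called first, only, known or untested is meant among the compounds shown, and "the series" means these compounds.

Measured so far in this series:

Compound 1 `O=C(OC1(C(=O)Nc2ccc([N+](=O)[O-])cc2)CCCCC1)c1ccc(C(F)(F)F)cc1`, in a functional assay on HepG2 cells (Homo sapiens) for inhibition, read by MTT assay, with a stated time of 72 h (a lower number here means a stronger inhibitor, a higher number a weaker inhibitor), compound 1 gives 29.1 nM.
Compound 2 `Cc1ccc(C(=O)OC2(C(=O)Nc3ccc([N+](=O)[O-])cc3)CCCCC2)cc1`, in this assay compound 2 gives 61.2 nM.
Compound 3 `O=C(OC1(C(=O)Nc2ccc([N+](=O)[O-])cc2)CCCCC1)c1ccc(Cl)cc1`, in this assay compound 3 gives 21.8 nM.

Compound 3 has the lowest number of the three, but only a 1.3-fold lower number from compound 1 to compound 3 (0.13 log units; within the scatter) separates it from compound 1, so the two cannot be ordered; against compound 2 it stands apart, a 2.8-fold lower number from compound 2 to compound 3 (0.45 log units; beyond the scatter).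

Compound 4 `COc1ccc(C(=O)OC2(C(=O)Nc3ccc([N+](=O)[O-])cc3)CCCCC2)cc1` is not yet measured. The change from compound 3 is methoxy in place of chloro on an aromatic carbon. Among the compounds with values here, none of the measured steps carries the same change. The nearest comparisons are the two replacements already made at this position: a 2.8-fold lower number from compound 2 to compound 3 (0.45 log units; beyond the scatter) and a 1.3-fold lower number from compound 1 to compound 3 (0.13 log units; within the scatter). Methoxy was not among the groups tried, so the direction rests on the observation that the only other non-halogen group at this place, in compound 2, gave the highest number. A modest rise in the number is therefore expected, of the order a 2.5-fold higher number from compound 3 to compound 4 (0.40 log units; beyond the scatter), with wide uncertainty. Compound 4 is estimated at 55 nM, with a likely range from 20 nM to 150 nM.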

Compound 4, half-maximal inhibitory concentration: 57.1 nM
Compound 4: the middle estimate sits 1.0-fold (0.02 log units) below what was measured; the measured number falls inside the stated range.
By their numbers in this assay, from the lowest: compounds 3, 1, 4 and 2 (each within the scatter of the next, the first and the last beyond it).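

In this assay, methoxy in place of chloro costs about as much as methyl in place of chloro, with a 2.6-fold higher number from compound 3 to compound 4 (0.42 log units; beyond the scatter) beyond the scatter, while a 1.1-fold lower number from compound 2 to compound 4 (0.03 log units; within the scatter) lies within it, so methoxy and methyl cannot be told apart at this position. Trifluoromethyl blurs any clean split: a 2.0-fold higher number from compound 1 to compound 4 (0.29 log units; within the scatter) is within the scatter, and compound 1 also cannot be separated from compound 3, although it does stand apart from compound 2. No measurement bearing on why the methoxy and chloro compounds differ is available here.

As far as these compounds go, whether bromo, fluoro or an amine at this position would group with chloro or with methoxy remains open. Also open, from the compounds shown here alone, is whether the same gaps would hold if a nitrile replaced the nitro group of the shared core.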